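The source may report more compounds than this note shows. Statements on the series, on what has been measured and on what is new or still open speak of the compounds shown alone.

Measured compounds and values in a functional assay on HEK293 cells for agonist activity at Bombesin receptor subtype-3 (Mus musculus), read by luminescence and calcium flux, with a stated time of 10 min; on this read-out higher numbers stand for an effect only at larger amounts of compound and lower numbers for an effect already at smaller amounts:
- compound 1, `CCC(C)(C)Cc1c[nH]c(CCc2ccc(-c3cccc(C)n3)cc2)n1`, compound 1 gives 106 nM
- compound 2, `CCC(C)(C)Cc1c[nH]c(CCc2ccc(-c3cccc(C#N)n3)cc2)n1`, compound 2 gives 115 nM
- compound 3, `CCC(C)(C)Cc1c[nH]c(CCc2ccc(-c3ccccc3C(=O)O)cc2)n1`, compound 3 gives 94 nM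

Compound 3 has the lowest of the three numbers in this assay, but its nearest neighbour is compound 1 with a 1.1-fold lower number from compound 1 to compound 3 (0.05 log units; within the scatter) and the furthest is compound 2 with a 1.2-fold lower number from compound 2 to compound 3 (0.09 log units; within the scatter), so all three sit within the scatter of one another and no order among them can be read from these values.

Compound 4, `CCC(C)(C)Cc1c[nH]c(CCc2ccc(-c3cccnc3)cc2)n1`, is not yet measured. Relative to compound 3 the change is pyridin-3-yl in place of 2-carboxyphenyl on an aromatic carbon.

Among the measured compounds shown here, the steps that bear on this are the two earlier swaps of the aryl group at this same position: a 1.1-fold lower number from compound 1 to compound 3 (0.05 log units; within the scatter) and a 1.2-fold lower number from compound 2 to compound 3 (0.09 log units; within the scatter), together with a 1.1-fold higher number from compound 1 to compound 2 (0.04 log units; within the scatter) on the other ring. Each of these lies within the scatter. Three aryl variants at this position have given essentially one number, so for compound 4 no step beyond the scatter is expected in this assay, in either direction; the expected step is a 1.1-fold higher number from compound 3 to compound 4 (0.05 log units; within the scatter).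

The estimate for compound 4 in this assay is therefore 105 nM, with a range from 40 nM to 280 nM.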

Compound 4, half-maximal effective concentration: 97 nM
Beside the measured number, compound 4's estimate is 1.1-fold (0.03 log units) above it; measured number inside the range.
By their numbers in this assay, from the lowest: compounds 3, 4, 1 and 2 (each within the scatter of the next).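

In this assay, pyridin-3-yl in place of 2-carboxyphenyl on an aromatic carbon para to a large group gives (a 1.0-fold higher number from compound 3 to compound 4 (0.01 log units; within the scatter)), so the loss of the carboxylic acid, with its hydrogen-bond donor and larger heavy-atom count, does not take the number outside the scatter. The result is the same when the unsubstituted pyridin-3-yl of compound 4 is set against the substituted 6-cyanopyridin-2-yl (a 1.2-fold lower number from compound 2 to compound 4 (0.07 log units; within the scatter)) and 6-methylpyridin-2-yl (a 1.1-fold lower number from compound 1 to compound 4 (0.04 log units; within the scatter)) groups, so neither the nitrile nor the methyl is needed to hold the number in this range, and all four aryl variants remain within the scatter of one another. No accompanying data explain why this position tolerates these changes.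

The compounds shown do not establish whether any group at this position can move the number beyond the scatter, since all four carry an aromatic ring there. An amine or a longer chain on that ring, or a saturated ring in its place, would test how far this tolerance extends.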